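Swapping a Chloro Anilide for a Dimethyl Anilide

This account rests on a few compounds, and the source may have more. Where it says the series, first, only, none or still open, it means among the compounds named here.

Three sulfonamides built on one shared core have been tested in a functional assay on M21 cells (Homo sapiens) for antiproliferative activity, read by sulforhodamine B assay, with a stated time of 48 h; a lower number here means a stronger inhibitor, a higher number a weaker inhibitor. Compound 1 `O=C1NCCN1c1ccc(S(=O)(=O)Nc2cccc(Br)c2)cc1` gives 59 nM, compound 2 `CCc1ccc(NS(=O)(=O)c2ccc(N3CCNC3=O)cc2)cc1` gives 480 nM, and compound 3 `O=C1NCCN1c1ccc(S(=O)(=O)Nc2ccc(Cl)cc2)cc1` gives 90 nM. Compound 3 stands second highest of the three numbers: the step of a 1.5-fold higher number from compound 1 to compound 3 (0.18 log units; within the scatter) is small, while the step of a 5.3-fold lower number from compound 2 to compound 3 (0.73 log units; beyond the scatter) is a clear one.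

Compound 4 `Cc1ccc(C)c(NS(=O)(=O)c2ccc(N3CCNC3=O)cc2)c1` has not yet been measured in this assay. It differs from compound 3 in one place: 2,5-dimethylphenyl in place of 4-chlorophenyl on a sulfonamide nitrogen. Going by the values given here, two measured steps bear on this change. The step of an 8.1-fold higher number from compound 1 to compound 2 (0.91 log units; beyond the scatter) shows that an alkyl-bearing phenyl on the sulfonamide nitrogen went with a weaker inhibitor, and the step of a 5.3-fold lower number from compound 2 to compound 3 (0.73 log units; beyond the scatter) shows the opposite move, chloro in place of ethyl, giving a stronger one. Compound 4 carries two methyl groups and no halogen, so a move in the same direction as compound 2 seems likely, although two methyl groups are not one ethyl group and the size of the step is uncertain. For compound 4 the expected step is a 3.3-fold higher number from compound 3 to compound 4 (0.52 log units; beyond the scatter), toward a weaker inhibitor. Compound 4 is therefore estimated at 300 nM in this assay, within a range from 100 nM to 900 nM.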

Compound 4, half-maximal inhibitory concentration: 27 nM
Beside the measured number, compound 4's estimate is 11-fold (1.05 log units) above it; the whole stated range lies above it.
By their numbers in this assay, from the lowest: compound 4; then compounds 1 and 3 (each within the scatter of the next); then compound 2.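

On the sulfonamide nitrogen, an alkyl-bearing phenyl does not by itself go with a weaker inhibitor in this assay: putting 2,5-dimethylphenyl in place of 4-chlorophenyl gives a 3.3-fold lower number from compound 3 to compound 4 (0.52 log units; beyond the scatter) rather than a rise, and putting it in place of 4-ethylphenyl gives an 18-fold lower number from compound 2 to compound 4 (1.25 log units; beyond the scatter), the largest step in the series. A halogen on this ring is not needed for a low number either, since replacing 3-bromophenyl gives a 2.2-fold lower number from compound 1 to compound 4 (0.34 log units; beyond the scatter), a modest step but one beyond the usual scatter. Compound 2 and compound 4 both carry only alkyl groups on this ring and still lie far apart, so a simple split into halogen and alkyl does not sort these four compounds.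

Nothing available here explains why 2,5-dimethylphenyl gives a lower number than 4-ethylphenyl. The compounds shown also leave open whether both methyl groups are needed, and how this ring would fare with a single methyl group, a methoxy group or an amine in their place.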